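A few compounds are considered here, and "the series" means these few. Any claim that something is new, unique, unknown or untested is made for them only; others in the source may bear on it.

Compound 1 `Cn1c(CN2CCN(c3ccccc3F)CC2)nc2ccccc21` is the reference point of the series. In an assay on CHO cells with metabotropic glutamate receptor 2 (Homo sapiens) as the target, read by FLIPR (on this read-out lower numbers stand for an effect already at smaller amounts and higher numbers for an effect only at larger amounts of compound), compound 1 gives 794 nM. Compound 2 `Cn1c(CN2CCN(c3ccccc3C(F)(F)F)CC2)nc2ccccc21` gives 316 nM in this assay, and the step of a 2.5-fold lower number from compound 1 to compound 2 (0.40 log units; beyond the scatter) is the only one measured so far; on the two numbers in hand compound 1 stands highest. Compound 3 `Cn1c(CN2CCN(c3ccc(C#N)cc3)CC2)nc2ccccc21` differs from compound 1 by 4-cyanophenyl in place of 2-fluorophenyl on an amine nitrogen in a ring. For the measured compounds named here, no measured step covers a nitrile, or a 4-substituted phenyl on an amine nitrogen in a ring; the step from compound 1 to compound 2 bears on it only in showing that exchanging the group on the aryl ring can move the number beyond the scatter. The expectation for compound 3 is therefore a step of modest size whose direction cannot be fixed from the data, entered here as a 1.3-fold lower number from compound 1 to compound 3 (0.10 log units; within the scatter). Compound 3 is estimated at 630 nM, with a range from 200 nM to 2000 nM.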

Compound 3, half-maximal effective concentration: > 12500 nM
Compound 3: only a limit was reported; the forecaster's own chance of this, stated with the estimate: 10%; middle value at least 19-fold (1.29 log units) from the limit.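

In this assay, 4-cyanophenyl in place of 2-fluorophenyl on the amine nitrogen in the ring gives an at least 15-fold higher number from compound 1 to compound 3 (1.19 log units; beyond the scatter), a large step where the earlier exchange on the aryl ring gave only the modest 2.5-fold lower number from compound 1 to compound 2 (0.40 log units; beyond the scatter). The reading for compound 3 is a limit of the assay and not a number: the limit of > 12500 nM in this assay, at which 1 of the 3 values shown sits. Going by these compounds, this position therefore does not accept every aryl group with only a modest shift, and the true size of this step remains unknown beyond the printed limit.

Compound 3 brings in the nitrile and the 4-substitution in a single change, and the compounds shown do not separate the two. 2-Cyanophenyl and 4-fluorophenyl would each carry only one of these features, and how unsubstituted phenyl behaves at this position also stays open.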